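A few compounds are considered here, and "the series" means these few. Any claim that something is new, unique, unknown or untested is made for them only; others in the source may bear on it.

Compound 1 `Cc1ccc(/C=C/C(=O)c2ccccc2NC(=O)NS(=O)(=O)c2ccc(C)cc2)cc1` is the reference point of this small set. For the measured compounds named here, in an ADME assay on the whole organism for cytotoxicity, with Artemia salina as the target, with a stated time of 24 h (on this read-out higher numbers stand for an effect only at larger amounts of compound and lower numbers for an effect already at smaller amounts), compound 1 gives 15.3 ug/mL, the second highest of the three numbers measured so far. Compound 2 `Cc1ccc(S(=O)(=O)NC(=O)Nc2ccccc2C(=O)/C=C/c2cccc(O)c2)cc1` gives 39.3 ug/mL in this assay, so that a 2.6-fold higher number from compound 1 to compound 2 (0.41 log units; beyond the scatter). Compound 3 `Cc1ccc(S(=O)(=O)NC(=O)Nc2ccccc2C(=O)/C=C/c2ccc(F)cc2)cc1` gives 3.96 ug/mL in this assay, so that a 3.9-fold lower number from compound 1 to compound 3 (0.59 log units; beyond the scatter) and a 9.9-fold lower number from compound 2 to compound 3 (1.00 log units; beyond the scatter).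

Compound 4 `Cc1ccc(S(=O)(=O)NC(=O)Nc2ccccc2C(=O)/C=C/c2ccccc2Cl)cc1` is not yet measured in this assay. Against compound 1 the change is 2-chlorophenyl in place of 4-methylphenyl on a double-bonded chain carbon bound to a double-bonded chain carbon. Going by the values given here, two measured steps bear on it. The exchange of the whole aryl group seen in a 2.6-fold higher number from compound 1 to compound 2 (0.41 log units; beyond the scatter) raised the number, whereas a 3.9-fold lower number from compound 1 to compound 3 (0.59 log units; beyond the scatter), a smaller change on that same ring, lowered it. Compound 4 also loses a methyl and gains a halogen, here a chlorine, on the ring at that place, and that precedent is taken as the closer one, so a modest fall in this assay is expected, a 2.4-fold lower number from compound 1 to compound 4 (0.37 log units; beyond the scatter). Compound 4 is therefore estimated at 6.5 ug/mL, with a range from 2.5 ug/mL to 16 ug/mL.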

Compound 4, concentration for half-maximal effect: 12.8 ug/mL
Estimate against measurement, compound 4: 2.0-fold (0.29 log units) below, and the stated range covers the measured number.
By their numbers in this assay, from the lowest: compound 3; then compounds 4 and 1 (each within the scatter of the next); then compound 2.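

In this assay the exchange of 4-methylphenyl for 2-chlorophenyl on a double-bonded chain carbon bound to a double-bonded chain carbon leaves compound 1 and compound 4 unseparated, with a 1.2-fold lower number from compound 1 to compound 4 (0.08 log units; within the scatter) and so no readable effect of this change. A halogen on this aryl ring therefore does not by itself go with the low number of compound 3, as a 3.2-fold higher number from compound 3 to compound 4 (0.51 log units; beyond the scatter) separates the two halogen-bearing groups, while a 3.1-fold lower number from compound 2 to compound 4 (0.49 log units; beyond the scatter) keeps 2-chlorophenyl apart from 3-hydroxyphenyl. No measurement is available here to explain these differences.

Whether the identity of the halogen or its place on the ring separates compound 3 from compound 4 stays open, as the compounds shown include neither 4-chlorophenyl nor 2-fluorophenyl. Also open, as far as these compounds go, is how an amine or a carboxylic acid on this aryl ring would read in this assay as a comparison with the hydroxy group of compound 2.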